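The source may hold more compounds than are shown below. What is called first, only, known or untested is meant among the compounds shown, and "the series" means these compounds.

Three compounds share one core and differ only in the ring attached to the thiocarbonyl carbon. Compound 1 `Cc1cccc(/C(N)=N/NC(=S)N2CCSCC2)n1` carries a thiomorpholin-4-yl group, compound 2 `Cc1cccc(/C(N)=N/NC(=S)N2CCOCC2)n1` a morpholin-4-yl group, and compound 3 `Cc1cccc(/C(N)=N/NC(=S)N2CCCCC2)n1` a piperidin-1-yl group. In a functional assay on A-375 cells (Homo sapiens) for cytotoxicity, read by MTT assay, with a stated time of 72 h (a lower number here means a stronger inhibitor, a higher number a weaker inhibitor), compound 1 gives 1400 nM, compound 2 gives 14000 nM, and compound 3 gives 1000 nM. Exchanging thiomorpholin-4-yl for morpholin-4-yl brought a 10-fold higher number from compound 1 to compound 2 (1.00 log units; beyond the scatter), whereas exchanging it for piperidin-1-yl brought a 1.4-fold lower number from compound 1 to compound 3 (0.15 log units; within the scatter); moving from morpholin-4-yl to piperidin-1-yl brought a 14-fold lower number from compound 2 to compound 3 (1.15 log units; beyond the scatter). Compound 3 thus holds the lowest number of the three, with compound 1 close to it and compound 2 far from it.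

Compound 4 `Cc1cccc(/C(N)=N/NC(=S)N2CCCC2)n1` differs from compound 3 in one place: pyrrolidin-1-yl in place of piperidin-1-yl on a thiocarbonyl carbon. For the measured compounds named here, none of the measured steps alters the size of this ring; each swaps one atom inside a six-membered ring while keeping the ring attached to the same thiocarbonyl carbon, so they bear on the new step only loosely. Both rings in the new pair contain a single hetero atom, the nitrogen joined to the thiocarbonyl carbon, which the rings of compound 1 and compound 2 do not. Going by the values given here, with no direct precedent, no step beyond the usual scatter is expected in either direction. The expected step is a 1.3-fold higher number from compound 3 to compound 4 (0.11 log units; within the scatter). Compound 4 is estimated at 1300 nM, within a range from 500 nM to 4000 nM.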

Compound 4, half-maximal inhibitory concentration: 2900 nM
Compound 4: middle estimate off by 2.2-fold (0.35 log units), on the low side; measured number inside the range.
By their numbers in this assay, from the lowest: compounds 3 and 1 (each within the scatter of the next); then compound 4; then compound 2.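

The earlier steps shown here only swapped one atom inside a six-membered ring, so they said nothing about the size of the ring itself. In this assay the size of the ring on the thiocarbonyl carbon also counts: with the nitrogen still the only hetero atom, pyrrolidin-1-yl in place of piperidin-1-yl gives a step beyond the scatter (a 2.9-fold higher number from compound 3 to compound 4 (0.46 log units; beyond the scatter)). Compound 4 also falls between the other two six-membered rings, separated from the thiomorpholin-4-yl compound (a 2.1-fold higher number from compound 1 to compound 4 (0.32 log units; beyond the scatter)) and from the morpholin-4-yl compound (a 4.8-fold lower number from compound 2 to compound 4 (0.68 log units; beyond the scatter)), so the five-membered ring keeps much of the activity but does not match compound 3 or compound 1.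

For the compounds shown here, with only two ring sizes compared here, it remains open whether a larger ring such as azepan-1-yl would continue this direction, or whether an open-chain group such as diethylamino would do as well as a ring at this place. The data shown offer no measured explanation for any of these differences.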